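Shared core series: aryl swap from compound 2 to compound 3

This account rests on a few compounds, and the source may have more. Where it says the series, first, only, none or still open, it means among the compounds named here.

Compound 1 `COc1ccc(C(=O)/C=C/c2ccc(-n3ccnc3)cc2)c2c1C=CC(C)(C)O2` sits at the limit of the assay: in a functional assay on HepG2 cells (Homo sapiens) for antiproliferative activity, read by MTT assay, with a stated time of 24 h (a higher number here means a weaker inhibitor, a lower number a stronger inhibitor), compound 1 gives > 10000 nM, a limit and not a number. Compound 2 `COc1ccc(C(=O)/C=C/c2ccc([N+](=O)[O-])cc2)c2c1C=CC(C)(C)O2` gives 2610 nM in this assay. This is the only number shown; the one further value, that of compound 1, sits at the limit (the limit of > 10000 nM in this assay, at which 1 of the 2 values shown sits). Among the measured compounds shown here, the single measured step, an at least 3.8-fold lower number from compound 1 to compound 2 (0.58 log units; beyond the scatter), is at least modest and beyond the scatter.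

Compound 3 `COc1ccc(C(=O)/C=C/c2cccc(Cl)c2)c2c1C=CC(C)(C)O2` is not yet measured. It differs from compound 2 as follows (3-chlorophenyl in place of 4-nitrophenyl on a double-bonded chain carbon bound to a double-bonded chain carbon). This touches the same aromatic ring as the measured step, but it removes the nitro rather than exchanging one ring substituent for another of the kind seen in compound 1, so the measured step bears on it only loosely. With the nitro gone and a chlorine entering, a shift back toward the weaker end is expected, of modest size, a 2.1-fold higher number from compound 2 to compound 3 (0.32 log units; beyond the scatter), though a step within the scatter cannot be excluded. The estimate for compound 3 in this assay is therefore 5500 nM, with a range from 1500 nM to 20000 nM.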

Compound 3, half-maximal inhibitory concentration: > 10000 nM
Compound 3: only a limit was reported (the forecaster's own chance of this, stated with the estimate: 35%); middle value at least 1.8-fold (0.25 log units) from the limit.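

In this assay, 3-chlorophenyl in place of 4-nitrophenyl gives an at least 3.8-fold higher number from compound 2 to compound 3 (0.58 log units; beyond the scatter), so the aryl group on this double-bonded chain carbon is shown to matter for a second replacement, one with no nitrogen in the group that enters. The true size of this step cannot be read, since compound 3 gives > 10000 nM, which is a limit of the assay and not a number. Two different replacements of the 4-nitrophenyl group, in compound 1 and compound 3, now end at the same limit, which leaves compound 2 as the only compound of the three with a number: the limit of > 10000 nM in this assay, at which 2 of the 3 values shown sit.

From the compounds shown here alone, compound 3 changes the group on the ring and its printed place in one step, so whether the nitro or its place carries the number of compound 2 stays open; 3-nitrophenyl and 4-chlorophenyl would separate the two. Going by these compounds, compound 1 and compound 3 cannot be ordered against each other, and it remains open whether another nitrogen group on the ring, such as an amine in 4-aminophenyl, gives a number within the range of the assay.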